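The compounds below may be only part of what the source reports. "The series", "measured", "known", "first", "only" and "open" are said of these compounds alone.

Going by the values given here, compound 1, `COCOc1cc(/C=C/C(=O)OCC(=O)NCc2ccco2)ccc1OCc1ccccc1`, is one of two compounds measured in a functional assay on CNE cells (Homo sapiens) for cytotoxicity, read by MTT assay, with a stated time of 72 h; a lower number here means a stronger inhibitor, a higher number a weaker inhibitor. In this assay compound 1 gives only a limit, > 200000 nM, and not a number. Compound 2, `CCOc1ccc(COc2c(OC)cc(/C=C/C(=O)N3CCN(Cc4ccc(Cl)c(Cl)c4)CC3)cc2OC)cc1`, likewise gives only a limit in this assay, > 200000 nM. Compound 1 therefore stands at the edge of what this assay can report, since both values sit at the limit of > 200000 nM in this assay, at which 2 of the 2 values shown sit. Compound 3, `COCOc1cc(/C=C/C(=O)OCC(=O)NN2CCOCC2)ccc1OCc1ccccc1`, has not yet been measured; it differs from compound 1 by morpholin-4-yl in place of (furan-2-yl)methyl on an amide-type nitrogen. Among the compounds with values here, no step between two measured compounds is available, so the effect of this change cannot be read from the data, and nothing beyond the usual scatter is expected. Because compound 1 already sits at the limit of > 200000 nM in this assay, at which 2 of the 2 values shown sit, the step from compound 1 to compound 3 is expected to be a number no higher from compound 1 to compound 3 (the limit leaves the size open), within the scatter. Compound 3 is accordingly estimated at 200000 nM, with a range from 100000 nM to 400000 nM, most likely reported again only as a limit.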

Compound 3, half-maximal inhibitory concentration: > 200000 nM
Compound 3 was reported as a limit; the forecaster's own chance of this, stated with the estimate: 80%; the middle value lies on the limit itself.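

Going by these compounds alone, compound 1 and compound 3 each give only a limit in this assay, so no step between them can be read. The compounds shown leave open how morpholin-4-yl and (furan-2-yl)methyl compare on the amide-type nitrogen, as every value sits at one ceiling: the limit of > 200000 nM in this assay, at which 3 of the 3 values shown sit.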